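Trading Cyano for 1-Hydroxyethyl

The compounds below may be only part of what the source reports. "The series", "measured", "known", "first", "only" and "open" are said of these compounds alone.

Among the measured compounds shown here, in a physicochemical assay for lipophilicity (on this read-out lower numbers stand for lower lipophilicity and higher numbers for higher lipophilicity), compound 2 `CC(=O)NCc1cccc(Cn2nc(NS(=O)(=O)c3ccc(Cl)s3)c3c(C#N)cccc32)c1` gives 2.5, the lower of the two numbers measured so far, while compound 1 `CC(=O)NCc1cccc(Cn2nc(NS(=O)(=O)c3ccc(Cl)s3)c3ccccc32)c1` gives 3.3. Compound 3 `CC(=O)NCc1cccc(Cn2nc(NS(=O)(=O)c3ccc(Cl)s3)c3c(C(C)O)cccc32)c1` differs from compound 2 at a single place: 1-hydroxyethyl in place of cyano on an aromatic carbon. For the measured compounds named here, the only measured step bearing on this, with cyano in place of hydrogen on an aromatic carbon, is a number 0.80 log units lower from compound 1 to compound 2 (beyond the scatter), and no measured compound carries 1-hydroxyethyl. A modest partial reversal of that step is expected: a number 0.30 log units higher from compound 2 to compound 3 (within the scatter). In this assay, compound 3 is estimated at 2.8, with an expected range of 2.3 to 3.3.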

Compound 3, distribution coefficient: 2.7
For compound 3 the middle estimate is 0.10 log units above the measured one; low and high end bracket the measured number.
By their numbers in this assay, from the lowest: compounds 2 and 3 (each within the scatter of the next); then compound 1.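

In this assay, putting 1-hydroxyethyl in place of cyano gives a number 0.20 log units higher from compound 2 to compound 3 (within the scatter), so the two groups cannot be told apart at this position. Among the compounds shown here, putting 1-hydroxyethyl in place of hydrogen gives a number 0.60 log units lower from compound 1 to compound 3 (beyond the scatter), so cyano is no longer the only group here that stands apart from hydrogen on this read-out. No measurement shown offers an explanation for this. On these data alone, whether an amine, a carboxylic acid or a longer chain on this aromatic carbon would fall near these two groups or near hydrogen remains open.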